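A few compounds are considered here, and "the series" means these few. Any claim that something is new, unique, unknown or untested is made for them only; others in the source may bear on it.

Compound 1 `COc1ccc2[nH]c(-c3nc(C)no3)cc2c1` carries a methoxy group on its two-ring core and a methyl on the outer five-membered ring. In a functional assay on Jurkat cells (Homo sapiens) for antiproliferative activity, read by WST assay, with a stated time of 72 h (on this read-out lower numbers stand for stronger inhibition and higher numbers for weaker inhibition), compound 1 gives 19900 nM. Compound 2 `COc1ccc2[nH]c(-c3nc(-c4ccc(Cl)cc4)no3)cc2c1` differs from it in one place, with an at least 2.5-fold higher number from compound 1 to compound 2 (0.40 log units; beyond the scatter). For compound 2 this assay reports only a limit, > 50000 nM. Compound 3 `COc1ccc(-c2noc(-c3cc4ccccc4[nH]3)n2)cc1` lacks the methoxy on the core and instead carries a methoxyphenyl on the outer ring. For compound 3 the assay likewise reports only a limit, > 50000 nM, so where it stands among the numbers is known only as the limit of > 50000 nM in this assay, at which 2 of the 3 values shown sit.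

Compound 4 `COc1ccc(-c2noc(-c3cc4cc(OC)ccc4[nH]3)n2)cc1` arises from compound 3 by methoxy in place of hydrogen on an aromatic carbon. Among the measured compounds shown here, no measured pair among the three compounds shows that exact change, so the only step known, from compound 1 to compound 2, concerns a different group and does not bear on it directly. The step from compound 3 to compound 4 is therefore expected to be a number no higher from compound 3 to compound 4 (the limit leaves the size open), which means the assay is most likely to report a limit again. Compound 4 is estimated at 50000 nM in this assay, within a range from 15000 nM to 150000 nM.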

Compound 4, half-maximal inhibitory concentration: > 50000 nM
Compound 4: a limit, no number; the forecaster's own chance of this, stated with the estimate: 70%; the middle value sits exactly at the limit.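

On the core of compound 3, methoxy in place of hydrogen brings no readable change in this assay; the steps to compound 4 from compound 3 and from compound 2 cannot be read, as each joins two limits. Among the compounds shown here, the one step that can be read is an at least 2.5-fold higher number from compound 1 to compound 4 (0.40 log units; beyond the scatter), so on the methoxy-bearing core, a 4-methoxyphenyl in place of the methyl gives the same kind of result as the 4-chlorophenyl of compound 2. Among the compounds shown, compound 1, with its methyl, is now the only one with a measured number, while the aryl-bearing compounds all share one ceiling: the limit of > 50000 nM in this assay, at which 3 of the 4 values shown sit.

From the compounds shown here alone, whether methoxy on the core helps, harms or does nothing remains open, as this change is seen here only in a pair where both values are limits. Also open, going by these compounds, is what happens to the number when the methyl of compound 1 gives way to something other than a substituted phenyl, such as an ethyl group, a longer chain or an aminomethyl group.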